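Aryl replacements on the shared core: compound 3

A few compounds are considered here, and "the series" means these few. Any claim that something is new, unique, unknown or untested is made for them only; others in the source may bear on it.

Among the compounds with values here, compound 1 `Cc1nc2c3ccccc3ccc2c2nc3c(ccc4ccccc43)c(-c3cccc4ccccc34)c12` stands with the lowest of the two numbers so far in a functional assay, read by spectrophotometry, with a stated time of 15 min (on this read-out lower numbers stand for stronger inhibition and higher numbers for weaker inhibition), where compound 1 gives 64.3 ug/mL. Its nearest neighbour is compound 2 `Cc1nc2c3ccccc3ccc2c2nc3c(ccc4ccccc43)c(-c3ccccc3Cl)c12`, which in this assay gives 74.6 ug/mL; the step of a 1.2-fold higher number from compound 1 to compound 2 (0.06 log units; within the scatter) is within the scatter, so the two values cannot be ordered.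

Compound 3 `Cc1ccc(-c2c3ccc4ccccc4c3nc3c2c(C)nc2c4ccccc4ccc32)cc1` is not yet measured. It differs from compound 1 as follows: 4-methylphenyl in place of naphthalen-1-yl on an aromatic carbon. Within the data shown here, the only measured step that bears on this change is a 1.2-fold higher number from compound 1 to compound 2 (0.06 log units; within the scatter), which swaps the same naphthalen-1-yl on the same aromatic carbon for another single six-membered aromatic ring of carbon only and leaves the number essentially where it was. A second exchange of the naphthalen-1-yl for a single ring, here 4-methylphenyl, is therefore expected to give a step of the same kind, a 1.1-fold higher number from compound 1 to compound 3 (0.04 log units; within the scatter), with no direction beyond the scatter. The value of compound 3 in this assay is estimated at 70 ug/mL, with a range from 35 ug/mL to 140 ug/mL.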

Compound 3, half-maximal inhibitory concentration: 68.7 ug/mL
Compound 3: middle estimate off by 1.0-fold (0.01 log units), on the high side; the measured number falls inside the stated range.
By their numbers in this assay, from the lowest: compounds 1, 3 and 2 (each within the scatter of the next).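

In this assay, the exchange of naphthalen-1-yl for 4-methylphenyl on this aromatic carbon, opposite the ring nitrogen, gives a 1.1-fold higher number from compound 1 to compound 3 (0.03 log units; within the scatter), and the exchange of 2-chlorophenyl for 4-methylphenyl on the same carbon gives a 1.1-fold lower number from compound 2 to compound 3 (0.04 log units; within the scatter). The flat result no longer rests on a single exchange: with compound 3, the series has two single-ring groups, one carrying chlorine and one carrying methyl, and neither can be separated from the two-ring naphthalen-1-yl, so compounds 1, 2 and 3 cannot be ordered at this position. No supporting measurement is available to account for this flat result.

All three groups at this position are aromatic rings of carbon only, so the compounds shown leave open whether an amine, a carboxylic acid or a pyridine ring on the same carbon would give a step beyond the scatter. Also open, going by these compounds, is whether a group with no aromatic ring, such as a short alkyl chain, would keep the number in the same range as compound 1, compound 2 and compound 3.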